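A few compounds are considered here, and "the series" means these few. Any claim that something is new, unique, unknown or untested is made for them only; others in the source may bear on it.

Compound 1 `Cc1ccc(S(=O)(=O)N2C/C(=C\c3cccnc3)C(=O)/C(=C/c3ccccc3F)C2)cc1`, compound 2 `O=C1/C(=C/c2cccnc2)CN(S(=O)(=O)c2ccc([N+](=O)[O-])cc2)C/C1=C\c1ccccc1F` and compound 3 `O=C1/C(=C/c2cccnc2)CN(S(=O)(=O)c2ccc(C(F)(F)F)cc2)C/C1=C\c1ccccc1F` share one core and differ in a single group on an aromatic carbon. All three were tested in a functional assay on SMMC-7721 cells (Homo sapiens) for cytotoxicity, read by MTT assay, with a stated time of 24 h; a higher number here means a weaker inhibitor, a lower number a stronger inhibitor. In this assay compound 1 gives 10300 nM. Compound 2 gives > 20000 nM, which is a limit of the assay and not a number. For the measured compounds named here, compound 3 gives 7900 nM, the only other exact number, and it cannot be separated from compound 1: the measured step is a 1.3-fold lower number from compound 1 to compound 3 (0.12 log units; within the scatter).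

Compound 4 `O=C1/C(=C/c2cccnc2)CN(S(=O)(=O)c2ccc(Br)cc2)C/C1=C\c1ccccc1F` keeps everything in compound 3 except one group, with bromo in place of trifluoromethyl on an aromatic carbon, para to a large group (bromo in place of trifluoromethyl on an aromatic carbon). Going by the values given here, no measured step makes this exact exchange, so the guide is the other swaps at this same place. Besides the step already given, there is an at least 1.9-fold higher number from compound 1 to compound 2 (0.28 log units; that floor lies within the scatter), whose size is only a floor. Among the compounds with values here, the one step that clears the scatter is an at least 2.5-fold lower number from compound 2 to compound 3 (0.40 log units; beyond the scatter), and it involves the nitro group, which compound 4 does not carry. No step beyond the scatter is therefore expected in this assay, and any drift is expected to be slight and towards a higher number. The expected change is a 1.1-fold higher number from compound 3 to compound 4 (0.06 log units; within the scatter). For compound 4 the estimated value is 9000 nM, with an expected range from 5000 nM to 16000 nM.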

Compound 4, half-maximal inhibitory concentration: 9100 nM
Beside the measured number, compound 4's estimate is 1.0-fold (0.00 log units) below it; the range from low to high includes it.
By their numbers in this assay, from the lowest: compounds 3, 4 and 1 (each within the scatter of the next). At a limit, above all of these: compound 2.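

In this assay, bromo proves to be a third group at this position that cannot be told apart from the others, with a 1.2-fold higher number from compound 3 to compound 4 (0.06 log units; within the scatter) and a 1.1-fold lower number from compound 1 to compound 4 (0.05 log units; within the scatter), so compounds 1, 3 and 4 form one cluster. Exchanging the four heavy atoms of trifluoromethyl for the single heavy atom of bromo thus gives no readable change here, and nitro remains the only group shown that goes against this cluster, now with a second step beyond the scatter: an at least 2.1-fold lower number from compound 2 to compound 4 (0.34 log units; beyond the scatter). That step is only a floor, as the value of compound 2 is a limit of the assay and not a number: the limit of > 20000 nM in this assay, at which 1 of the 4 values shown sits.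

The compounds shown leave open whether a group of another kind on this aromatic carbon, such as an amine or a carboxylic acid, would move the number clear of the cluster, and in which direction. As far as these compounds go, how far compound 2 really lies from the other three also stays unknown.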